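This account rests on a few compounds, and the source may have more. Where it says the series, first, only, none or still open, it means among the compounds named here.

Going by the values given here, in an ADME assay on the whole organism (Macaca fascicularis) for pharmacokinetics, read by LC-MS, using cassette dosing, at a dose of 1 mg/kg by the oral route (on this read-out lower numbers stand for lower exposure and higher numbers for higher exposure at the dose given), compound 3 `CCCCN(c1nc2c(NS(C)(=O)=O)cccc2o1)[C@H](C)c1ccc(-c2ccccc2-c2nnn[nH]2)cc1` gives 73.8 ng.h/mL, the lowest of the three numbers measured so far. Compound 2 `CCCCN(c1nc2c(C(=O)O)cccc2o1)[C@H](C)c1ccc(-c2ccccc2-c2nnn[nH]2)cc1` gives 429 ng.h/mL, and compound 1 `C[C@H](c1ccc(-c2cc(Cl)ccc2-c2nc(=O)o[nH]2)cc1)N(CC1CC1)c1nc2c(C(=O)O)cccc2o1` gives 1300 ng.h/mL. Compound 4 `CCCCN(c1nc2c(-c3nccn3C)cccc2o1)[C@H](C)c1ccc(-c2ccccc2-c2nnn[nH]2)cc1` has not yet been measured; it differs from compound 3 by 1-methyl-1H-imidazol-2-yl in place of methanesulfonamido on an aromatic carbon. Among the compounds with values here, the only measured single change is a 5.8-fold lower number from compound 2 to compound 3 (0.76 log units; beyond the scatter), which shows that exchanging the group at this position can move exposure beyond the scatter, but no measured step replaces the methanesulfonamido with an aromatic ring. The direction for compound 4 is therefore uncertain, and a step of moderate size either way is possible. Compound 4 is expected to give about 150 ng.h/mL, between 30 ng.h/mL and 700 ng.h/mL. The expected step is a 2.0-fold higher number from compound 3 to compound 4 (0.31 log units; beyond the scatter).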

Compound 4, area under the concentration-time curve: 152 ng.h/mL
Beside the measured number, compound 4's estimate is 1.0-fold (0.01 log units) below it, and the stated range covers the measured number.
By their numbers in this assay, from the lowest: compound 3; then compound 4; then compound 2; then compound 1.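

In this assay, an aromatic ring at this position on the shared core gives a 2.1-fold higher number from compound 3 to compound 4 (0.31 log units; beyond the scatter) and also a 2.8-fold lower number from compound 2 to compound 4 (0.45 log units; beyond the scatter). With the rest of the structure held constant, the three groups now rank from carboxy at the top, through 1-methyl-1H-imidazol-2-yl, to methanesulfonamido at the bottom, with each step beyond the scatter. No measurement here explains this order. Still open, on these data alone, is where an amine or a primary amide would fall at this position. It is also unclear whether the imidazole ring without its methyl would give a similar number.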